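The source may hold more compounds than are shown below. What is called first, only, known or untested is meant among the compounds shown, and "the series" means these compounds.

Three compounds share one core and differ only in the halogen pattern on the phenyl ring carried by a saturated chain carbon bound to an amine nitrogen in a ring. In an assay on FRT cells for positive allosteric modulation of Cystic fibrosis transmembrane conductance regulator variant N1303K (Homo sapiens), in the presence of a further agent that is not named here (on this read-out lower numbers stand for an effect already at smaller amounts and higher numbers for an effect only at larger amounts of compound), compound 1 `COc1ccc2[nH]c3c(c2c1)CCNC31CCN(Cc2c(F)ccc(Cl)c2F)CC1` gives 1500 nM, compound 2 `COc1ccc2[nH]c3c(c2c1)CCNC31CCN(Cc2ccc(F)c(Cl)c2F)CC1` gives 4500 nM, and compound 3 `COc1ccc2[nH]c3c(c2c1)CCNC31CCN(Cc2cc(F)ccc2F)CC1` gives 11100 nM. Compound 3 thus stands at the highest number of the three: the steps are a 3.0-fold higher number from compound 1 to compound 2 (0.48 log units; beyond the scatter), a 7.4-fold higher number from compound 1 to compound 3 (0.87 log units; beyond the scatter) and a 2.5-fold higher number from compound 2 to compound 3 (0.39 log units; beyond the scatter).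

Compound 4 `COc1ccc2[nH]c3c(c2c1)CCNC31CCN(Cc2cc(F)cc(F)c2)CC1` is the next member. The change from compound 3 is 3,5-difluorophenyl in place of 2,5-difluorophenyl on a saturated chain carbon bound to an amine nitrogen in a ring. Among the compounds with values here, none of the measured steps is of this kind: each of them removes or keeps a chlorine as well as moving fluorines, whereas here only the position of one fluorine on the ring changes while the atoms stay the same. The measured steps show that the ring pattern does move the number, but all of them were modest. Without a closer precedent, compound 4 is expected to stay near compound 3, with the step of a 1.2-fold higher number from compound 3 to compound 4 (0.07 log units; within the scatter) expected to lie at or just beyond the scatter. The estimate for compound 4 is 13000 nM, within a range from 5000 nM to 35000 nM.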

Compound 4, half-maximal effective concentration: 11100 nM
Estimate against measurement, compound 4: 1.2-fold (0.07 log units) above; low and high end bracket the measured number.
By their numbers in this assay, from the lowest: compound 1; then compound 2; then compounds 3 and 4 (each within the scatter of the next).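

Moving one fluorine, so that 3,5-difluorophenyl replaces 2,5-difluorophenyl on a saturated chain carbon bound to an amine nitrogen in a ring, leaves the result in this assay where it was, with no change at the digits printed from compound 3 to compound 4 (within the scatter) as the step. For this pair, the position of that one fluorine makes no difference this read-out can detect, although the earlier compounds had shown that the halogen pattern as a whole can shift the number. The gaps to the chlorine-bearing compounds remain beyond the scatter, with a 2.5-fold higher number from compound 2 to compound 4 (0.39 log units; beyond the scatter) and a 7.4-fold higher number from compound 1 to compound 4 (0.87 log units; beyond the scatter) as the steps, but each swaps the chlorine and moves fluorines at once, so they cannot be credited to any single atom, and nothing measured here explains the flat result between the two difluorophenyl groups.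

From the compounds shown here alone, it remains open whether 3-chloro-5-fluorophenyl would bring the number back toward those of compound 1 and compound 2. Going by these compounds, the effect of a nitrile or a methoxy group on this ring also remains unknown.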